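A Methyl Added to the Fluorophenyl Arm

The source may hold more compounds than are shown below. What is called first, only, known or untested is meant among the compounds shown, and "the series" means these compounds.

compound 1 `C=CCn1c(=O)/c(=C\c2cccc(F)c2)[nH]c(=O)/c1=C\c1ccccc1OC`: 25600 nM
compound 2 `C=CCn1c(=O)/c(=C\c2ccccc2OC)[nH]c(=O)/c1=C\c1ccccc1OC`: 21500 nM

Going by the values given here, in a functional assay on NCI-H1975 cells (Homo sapiens) for cytotoxicity, read by CCK-8 assay, with a stated time of 72 h (on this read-out lower numbers stand for stronger inhibition and higher numbers for weaker inhibition), compound 1 gives 25600 nM, the higher of the two numbers measured so far. Compound 2 gives 21500 nM, and the step of a 1.2-fold lower number from compound 1 to compound 2 (0.08 log units; within the scatter) stays within the scatter, so the two compounds cannot be told apart on these numbers. Compound 3 `C=CCn1c(=O)/c(=C\c2cc(F)ccc2C)[nH]c(=O)/c1=C\c1ccccc1OC` has not yet been measured. It differs from compound 1 by methyl in place of hydrogen on an aromatic carbon.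

Among the compounds with values here, only one measured step exists, and it exchanges the whole 3-fluorophenyl for 2-methoxyphenyl rather than adding a methyl to the ring that carries the fluoro group, so no measured step bears directly on this change. That one step left the number within the scatter, and nothing measured points in either direction for a methyl at this place. The expectation is therefore a step of a 1.0-fold lower number from compound 1 to compound 3 (0.01 log units; within the scatter) that does not go beyond the scatter, and compound 3 is estimated at 25000 nM, with a range from 10000 nM to 60000 nM.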

Compound 3, half-maximal inhibitory concentration: 7300 nM
Estimate against measurement, compound 3: 3.4-fold (0.53 log units) above; the measured number lies below the stated range.
By their numbers in this assay, from the lowest: compound 3; then compounds 2 and 1 (each within the scatter of the next).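

Adding a single methyl to the fluorophenyl arm gives a 3.5-fold lower number from compound 1 to compound 3 (0.54 log units; beyond the scatter) in this assay and is the first change in this small set to move the number beyond the scatter, showing that this aromatic carbon, ortho to a large group and para to a fluoro group, is not indifferent to substitution. The 5-fluoro-2-methylphenyl arm also separates from the 2-methoxyphenyl arm, with a 2.9-fold lower number from compound 2 to compound 3 (0.47 log units; beyond the scatter) while the earlier exchange of 3-fluorophenyl for 2-methoxyphenyl could not be told apart, so the arm can change the number even though that first exchange did not. No measurement here speaks to why the methyl lowers the number.

The compounds shown leave open whether an ethyl group, a chloro group or an amine on the same carbon would lower the number further or raise it again. They also leave open whether a methyl at this place would give a similar step on a phenyl ring with no fluoro group, which would show whether the two groups need each other.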